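Second hydroxy on the ketone-side ring of a chalcone

The source may hold more compounds than are shown below. What is called first, only, known or untested is meant among the compounds shown, and "the series" means these compounds.

Three chalcones sharing one core have been measured in a functional assay, read by Griess assay, with a stated time of 2.5 h; a lower number here means a stronger inhibitor, a higher number a weaker inhibitor. Compound 1 `COc1cc(OC)c(OC)cc1/C=C/C(=O)c1ccc(C)cc1` gives 2.18 ug/mL. Compound 2 `COc1cc(OC)c(OC)cc1/C=C/C(=O)c1cc(Cl)ccc1O` gives 2.32 ug/mL. Compound 3 `COc1cc(OC)c(OC)cc1/C=C/C(=O)c1ccc(O)cc1` gives 2.5 ug/mL. Compound 3 has the highest of the three numbers, yet its steps to both others fall within the scatter: a 1.1-fold higher number from compound 1 to compound 3 (0.06 log units; within the scatter) and a 1.1-fold higher number from compound 2 to compound 3 (0.03 log units; within the scatter), and the remaining pair shows a 1.1-fold higher number from compound 1 to compound 2 (0.03 log units; within the scatter).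

Compound 4 `COc1cc(OC)c(OC)cc1/C=C/C(=O)c1ccc(O)cc1O` differs from compound 3 by hydroxy in place of hydrogen on an aromatic carbon.

Within the data shown here, two measured steps bear on this change. The step from compound 1 to compound 3 put a hydroxy in place of methyl on an aromatic carbon of the same ring and moved the number only within the scatter, and the step from compound 2 to compound 3 rearranged a hydroxy and removed a chloro on that ring with the same result. Every change so far on the ring attached to the carbonyl has left the number where it was. Compound 4 is therefore expected to show no step beyond the scatter, with a 1.0-fold lower number from compound 3 to compound 4 (0.02 log units; within the scatter). Compound 4 is estimated at 2.4 ug/mL, within the range 1.2 ug/mL to 5 ug/mL.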

Compound 4, half-maximal inhibitory concentration: 2.76 ug/mL
The estimate for compound 4 lay 1.2-fold (0.06 log units) below the measured number; the measured number falls inside the stated range.
By their numbers in this assay, from the lowest: compounds 1, 2, 3 and 4 (each within the scatter of the next).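

In this assay, adding a second hydroxy to the ketone-side ring, the change from 4-hydroxyphenyl to 2,4-dihydroxyphenyl, leaves the number within the scatter (a 1.1-fold higher number from compound 3 to compound 4 (0.04 log units; within the scatter)), so a hydroxy ortho to a large group and meta to a hydroxy group is tolerated without a measurable change. The wider comparisons also stay within the scatter (a 1.2-fold higher number from compound 2 to compound 4 (0.08 log units; within the scatter)) and (a 1.3-fold higher number from compound 1 to compound 4 (0.10 log units; within the scatter)), which means that the four ketone-side rings, carrying methyl, chloro with hydroxy, one hydroxy or two hydroxy groups, cannot be told apart in this assay, and none of the four goes against that reading. Nothing available here bears on why this added hydroxy leaves the number within the scatter.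

It remains open whether any group on this ring can move the number beyond the scatter, since the compounds shown offer only small substituents of these few kinds. An amine, a carboxylic acid or a methoxy at the same ortho place could test this, as could a change on the trimethoxy-bearing side of the shared core, which stays the same in all four compounds.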